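Moving a bromine on the benzylsulfanyl arm of a thiadiazolopyrimidine

A few compounds are considered here, and "the series" means these few. Any claim that something is new, unique, unknown or untested is made for them only; others in the source may bear on it.

Going by the values given here, compound 1, `Cc1cc(N2CC[C@@H](C)[C@@H](N(C)c3ncnc4[nH]ccc34)C2)n2nc(SCc3ccccc3Br)nc2n1`, is one of two compounds measured in a functional assay on HGC-27 cells (Homo sapiens) for inhibition, read by MTT assay, with a stated time of 72 h (a higher number here means a weaker inhibitor, a lower number a stronger inhibitor), where compound 1 gives 21300 nM. Compound 2, `CCCCCc1c(C)nc2nc(SCc3ccc(Cl)cc3)nn2c1N1CC[C@@H](C)[C@@H](N(C)c2ncnc3[nH]ccc23)C1`, reaches only a limit of the assay, > 100000 nM, in this assay, as shown by the limit of > 100000 nM in this assay, at which 1 of the 2 values shown sits. Compound 3, `Cc1cc(N2CC[C@@H](C)[C@@H](N(C)c3ncnc4[nH]ccc34)C2)n2nc(SCc3ccc(Br)cc3)nc2n1`, has the same atoms as compound 1 joined differently: 4-bromophenyl in place of 2-bromophenyl on a saturated chain carbon bound to a sulfur. Among the compounds with values here, no measured pair differs in one place, so no step size is known. The estimated step of a 1.4-fold higher number from compound 1 to compound 3 (0.15 log units; within the scatter) is expected to stay within the usual scatter. Compound 3 is expected to give 30000 nM, with a range from 10000 nM to 100000 nM.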

Compound 3, half-maximal inhibitory concentration: 19500 nM
Beside the measured number, compound 3's estimate is 1.5-fold (0.19 log units) above it; the measured number falls inside the stated range.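

In this assay, the step for 4-bromophenyl in place of 2-bromophenyl is a 1.1-fold lower number from compound 1 to compound 3 (0.04 log units; within the scatter). Going by these compounds alone, this is the first step read between compounds that differ in one place, and it shows that the two bromophenyl forms cannot be told apart on a saturated chain carbon bound to a sulfur. Nothing measured here explains this result. Still open, going by these compounds, is whether a different group at this place, such as a carboxylic acid or an amine in place of the bromine, would give a clearly different number.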